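Working notes: fluoro for methyl on the aryl ring

A few compounds are considered here, and "the series" means these few. Any claim that something is new, unique, unknown or untested is made for them only; others in the source may bear on it.

Compound 1 `COc1ccc(Cl)cc1NC(=O)N1CC2(CCN(S(=O)(=O)N3CCC(C)CC3)CC2)C1`: > 10000 nM
Compound 2 `Cc1ccc(NC(=O)CN2CCN(S(=O)(=O)N3CCC(C)CC3)CC2)cc1`: 4100 nM
Compound 3 `COc1ccc(Cl)cc1NC(=O)CN1CCN(S(=O)(=O)N2CCN(C(=O)N3CCCCCC3)CC2)CC1`: > 10000 nM

In an assay on HEK293 cells for activation of potassium channel subfamily T member 1 (Homo sapiens), read by thallium flux (on this read-out higher numbers stand for an effect only at larger amounts of compound and lower numbers for an effect already at smaller amounts), compound 1 reaches only the assay limit, > 10000 nM. Compound 3 likewise sits at the limit, > 10000 nM. Compound 2 alone gives a number, 4100 nM. That leaves compound 2 as the single measured point, set against (the limit of > 10000 nM in this assay, at which 2 of the 3 values shown sit).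

Compound 4 `CC1CCN(S(=O)(=O)N2CCN(CC(=O)Nc3ccc(F)cc3)CC2)CC1` differs from compound 2 by fluoro in place of methyl on an aromatic carbon. Within the data shown here, no pair of measured compounds differs in one place, so no measured step informs this change. Fluoro in place of methyl on an aromatic carbon is expected to move the value little, if at all, beyond the scatter, in either direction. Compound 4 is therefore estimated at 5000 nM, between 2000 nM and 15000 nM. The expected step from compound 2 to compound 4 is a 1.2-fold higher number from compound 2 to compound 4 (0.09 log units; within the scatter).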

Compound 4, half-maximal effective concentration: > 10000 nM
Compound 4: only a limit was reported; the forecaster's own chance of this, stated with the estimate: 35%; middle value at least 2.0-fold (0.30 log units) from the limit.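

In this assay, among these compounds, fluoro in place of methyl on the aromatic carbon gives an at least 2.4-fold higher number from compound 2 to compound 4 (0.38 log units; beyond the scatter), the first step between compounds that differ in one place. This position is therefore not indifferent to the change, and of these two groups only methyl gives a number. Compound 4 stands at a limit, so the step has a floor but no measured size: the limit of > 10000 nM in this assay, at which 3 of the 4 values shown sit.

As far as these compounds go, whether ethyl, trifluoromethyl or a nitrile on this carbon would give a number, and how any such number would compare with that of compound 2, stays open.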